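Swapping an Aryl Group for Thiophene on a Shared Core

The compounds below may be only part of what the source reports. "The series", "measured", "known", "first", "only" and "open" are said of these compounds alone.

For the measured compounds named here, compound 2 `Cc1ccccc1-c1ccccc1OC(C)C1=NCCN1` gives 832 nM in an assay on CHO cells for displacement of a labelled ligand from Alpha-2B adrenergic receptor (Homo sapiens) (a lower number here means a stronger inhibitor, a higher number a weaker inhibitor), the lowest of the two numbers measured so far. Compound 1 `CC(Oc1ccccc1-c1ccncc1)C1=NCCN1` gives 2690 nM in this assay. Going by the values given here, the only measured step, a 3.2-fold lower number from compound 1 to compound 2 (0.51 log units; beyond the scatter), exchanged one aromatic ring on the shared core for another. Compound 3 `CC(Oc1ccccc1-c1cccs1)C1=NCCN1` differs from compound 2 by thiophen-2-yl in place of 2-methylphenyl on an aromatic carbon. Among the compounds with values here, no measured step exchanges these two groups directly, so a small move back toward the number of compound 1 is expected, and the expected step is a 1.6-fold higher number from compound 2 to compound 3 (0.19 log units; within the scatter). Compound 3 is therefore estimated at 1300 nM, ranging from 400 nM to 4000 nM.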

Compound 3, inhibition constant: 214 nM
Estimate against measurement, compound 3: 6.1-fold (0.78 log units) above, and the stated range ends above it.
By their numbers in this assay, from the lowest: compound 3; then compound 2; then compound 1.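

At this aromatic carbon, the choice of ring moves the number widely: thiophen-2-yl gives the lowest number of the three in this assay, ahead of 2-methylphenyl (a 3.9-fold lower number from compound 2 to compound 3 (0.59 log units; beyond the scatter)) and further ahead of pyridin-4-yl (a 13-fold lower number from compound 1 to compound 3 (1.10 log units; beyond the scatter)). For the compounds shown here, a six-membered aromatic ring is therefore not needed here for the lowest number so far. Nothing available explains this result. Thiophen-2-yl differs from 2-methylphenyl in both ring size and its sulfur, and these compounds cannot separate the two. As far as these compounds go, how plain phenyl, furan-2-yl or thiophen-3-yl would compare remains open.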